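A methyl on the sulfonyl ring and cytotoxicity in lung cells

The source may hold more compounds than are shown below. What is called first, only, known or untested is meant among the compounds shown, and "the series" means these compounds.

Three cyclic urea sulfonamides have been compared in a functional assay on A549 cells (Homo sapiens) for cytotoxicity; a higher number here means a weaker inhibitor, a lower number a stronger inhibitor. Compound 1 `Cc1ccc(S(=O)(=O)N2CC(c3ccccc3)NC2=O)cc1` gives 12500 nM in this assay. Compound 2 `Cc1ccc(C2CNC(=O)N2S(=O)(=O)c2ccccc2)cc1` is built from the same atoms joined differently; the difference between the two cores is not broken down here. In this assay compound 2 gives 157000 nM, so that compound 1 holds the lowest of the two numbers. Compound 3 `Cc1ccc(C2CNC(=O)N2S(=O)(=O)c2ccc(C)cc2)cc1` returns only a limit of the assay, > 302000 nM. That reading is the limit of > 302000 nM in this assay, at which 1 of the 3 values shown sits.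

Compound 3 differs from compound 2 by methyl in place of hydrogen on an aromatic carbon. This change brought an at least 1.9-fold higher number from compound 2 to compound 3 (0.28 log units; that floor lies within the scatter). Compound 4 `Cc1ccc(C2CN(S(=O)(=O)c3ccc(C)cc3)C(=O)N2)cc1` differs from compound 1 by methyl in place of hydrogen on an aromatic carbon, the same change at the same place, here made on the core of compound 1 rather than on that of compound 2. The expected step is a 2.0-fold higher number from compound 1 to compound 4 (0.30 log units; within the scatter), and it rests on the measured at least 1.9-fold higher number from compound 2 to compound 3 (0.28 log units; that floor lies within the scatter), whose floor sits within the scatter, so only a modest weakening is assumed. Compound 4 is therefore expected to give about 25000 nM in this assay, most likely between 8000 nM and 80000 nM.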

Compound 4, half-maximal inhibitory concentration: > 302000 nM
Compound 4: only a limit was reported; the forecaster's own chance of this, stated with the estimate: 5%; middle value at least 12-fold (1.08 log units) from the limit.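

Methyl in place of hydrogen on the sulfonyl ring of the core of compound 1 brought an at least 24-fold higher number from compound 1 to compound 4 (1.38 log units; beyond the scatter) in this assay. This shows that the change can carry a large penalty on this core, but it does not show that the penalty is larger here than on the core of compound 2, since the two steps cannot be told apart: the same change on two cores in this assay, an at least 1.9-fold higher number (0.28 log units; that floor lies within the scatter) from compound 2 to compound 3 and an at least 24-fold higher number (1.38 log units; beyond the scatter) from compound 1 to compound 4; the limit leaves it open whether they differ Neither step has a known full size, and the step seen on one core therefore gives no reliable forecast for the other: the limit of > 302000 nM in this assay, at which 2 of the 4 values shown sit.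

The compounds shown leave open how the number would move with another group at the same place on the sulfonyl ring, such as methoxy, chlorine, an amine or a carboxylic acid. They also leave open whether a smaller substituent such as fluorine would keep the number of compound 1 clear of the limit of this assay.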